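Pyridin-3-yl in Place of Phenyl: Expected Stability

The compounds below may be only part of what the source reports. "The series", "measured", "known", "first", "only" and "open" are said of these compounds alone.

Compound 2 `Cc1onc(-c2ccccc2)c1[C@@H]1C[C@@](C)(c2ccc(F)cc2F)N=C(N)S1` stands lowest of the two compounds measured in an ADME assay on microsomes from liver (Rattus norvegicus) for metabolic stability, with a stated time of 10 min, tested at 0.5 uM (on this read-out higher numbers stand for a more stable compound and lower numbers for a less stable compound), where compound 2 gives 13%. Going by the values given here, compound 1 `Cc1noc(C)c1[C@@H]1C[C@@](C)(c2ccc(F)cc2F)N=C(N)S1` gives 78%, so the one measured step, a number 65 percentage points lower from compound 1 to compound 2 (beyond the scatter), is large and goes down. Compound 3 `Cc1onc(-c2cccnc2)c1[C@@H]1C[C@@](C)(c2ccc(F)cc2F)N=C(N)S1` alters the group that this step introduced: pyridin-3-yl in place of phenyl on an aromatic carbon. Among the compounds with values here, no measured pair covers a pyridin-3-yl for phenyl swap, so the step from compound 1 to compound 2 bears only indirectly: it shows that what sits at this position can move the read-out by a great deal, but not how a six-membered aromatic ring with 1 hetero atom compares with one of carbon only. Compound 3 is therefore expected to stay near compound 2, with a moderate rise possible, a number 17 percentage points higher from compound 2 to compound 3 (beyond the scatter). Compound 3 is estimated at 30%, within 10% to 60%.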

Compound 3, percent of the compound remaining: 5%
The estimate for compound 3 lay 25 percentage points above the measured number, outside the stated range (below it).
By their numbers in this assay, from the lowest: compounds 3 and 2 (each within the scatter of the next); then compound 1.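

In this assay, swapping phenyl for pyridin-3-yl adds a ring nitrogen and a hydrogen-bond acceptor at this position, yet the swap gives a number 8 percentage points lower from compound 2 to compound 3 (within the scatter), so these two rings cannot be told apart on this read-out. Compared with the methyl group of compound 1, pyridin-3-yl gives a number 73 percentage points lower from compound 1 to compound 3 (beyond the scatter), so a large step appears with a six-membered aromatic ring holding a hetero atom as well as with one of carbon only. Nothing shown here gives a reason for these numbers.

Still open, as far as these compounds go, is whether a small non-aromatic group at this position, such as an ethyl or a cyclopropyl, would read closer to compound 1 or to compound 2. Also open, from the compounds shown here alone, is how an aromatic ring carrying a methoxy group or a carboxylic acid would read here.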